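Swapping the aryl group on a tolerated hexyl compound

The compounds below may be only part of what the source reports. "The series", "measured", "known", "first", "only" and "open" are said of these compounds alone.

Values in an ADME assay on cells (Macrophage) for cytotoxicity, read by resazurin assay, with a stated time of 48 h (a lower number here means that less compound is tolerated, a higher number that more compound is tolerated), so far:
compound 1 `O=C(/C=C/c1c(F)cccc1Cl)c1ccc(OCc2cn(Cc3ccc(Br)cc3)nn2)cc1O` | 65800 nM
compound 2 `CCCCCCn1cc(COc2ccc(C(=O)/C=C/c3ccc(OC)cc3)c(O)c2)nn1` | "not determined" (no result reported)
compound 3 `CCCCCCn1cc(COc2ccc(C(=O)/C=C/c3ccc(Br)cc3)c(O)c2)nn1` | > 100000 nM

In this assay compound 3 reads > 100000 nM and that is a limit, not a number. Compound 4 `CCCCCCn1cc(COc2ccc(C(=O)/C=C/c3c(F)cccc3Cl)c(O)c2)nn1` has 2-chloro-6-fluorophenyl in place of the 4-bromophenyl of compound 3, on a double-bonded chain carbon bound to a double-bonded chain carbon (2-chloro-6-fluorophenyl in place of 4-bromophenyl on a double-bonded chain carbon bound to a double-bonded chain carbon). Among the measured compounds shown here, no measured pair isolates this change. The nearest guide is compound 1, which also carries 2-chloro-6-fluorophenyl and reads 65800 nM in this assay, so a small move toward less tolerated compound is expected, possibly within the usual scatter. The estimated change is an at least 1.1-fold lower number from compound 3 to compound 4 (0.07 log units; that floor lies within the scatter) in size. For compound 4 the expected value is 85000 nM (range 40000 nM to 150000 nM).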

Compound 4, half-maximal cytotoxic concentration: > 100000 nM
Compound 4 ended at the assay's limit; the forecaster's own chance of this, stated with the estimate: 45%; middle value at least 1.1-fold (0.07 log units) from the limit.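

In this assay compound 4 gives > 100000 nM, which is a limit of the assay and not a number. With 2-chloro-6-fluorophenyl in place of 4-bromophenyl, the hexyl compounds therefore stay at the same limit, and the step between compound 3 and compound 4 cannot be read: the limit of > 100000 nM in this assay, at which 2 of the 4 values shown sit. With 2-chloro-6-fluorophenyl kept, pentyl in place of 4-bromophenyl on a saturated chain carbon bound to an aromatic nitrogen gives an at least 1.5-fold higher number from compound 1 to compound 4 (0.18 log units; that floor lies within the scatter).

On these data alone, whether an amine or a carboxylic acid on the aryl ring would bring a hexyl compound within the readable range remains open.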